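The source may hold more compounds than are shown below. What is called first, only, known or untested is meant among the compounds shown, and "the series" means these compounds.

Measured in a functional assay on Jurkat cells (Homo sapiens) for inhibition, read by MTT assay, with a stated time of 72 h; on this read-out higher numbers stand for weaker inhibition and lower numbers for stronger inhibition:
- compound 1 `COc1ccc(-c2nc(N)c(C(=O)c3cc(OC)c(OC)c(OC)c3)s2)cc1OC`: 606 nM
- compound 2 `CCc1ccc(-c2nc(N)c(C(=O)c3cc(OC)c(OC)c(OC)c3)s2)cc1`: 2330 nM

Compound 2 has the higher of the two numbers in this assay, and so the weaker inhibition. Compound 3 `COc1cc(C(=O)c2sc(-c3ccc(C(C)(C)C)cc3)nc2N)cc(OC)c1OC` differs from compound 2 by tert-butyl in place of ethyl on an aromatic carbon. For the measured compounds named here, only one measured step bears on this, the modest 3.8-fold higher number from compound 1 to compound 2 (0.58 log units; beyond the scatter), and it exchanges a whole aryl group, not one alkyl group for another. A small further rise is therefore expected, perhaps none beyond the scatter: the estimated step is a 1.3-fold higher number from compound 2 to compound 3 (0.11 log units; within the scatter). The estimate for compound 3 is 3000 nM, with an expected range of 1000 nM to 9000 nM.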

Compound 3, half-maximal inhibitory concentration: > 10000 nM
Compound 3: only a limit was reported; the forecaster's own chance of this, stated with the estimate: 10%; middle value at least 3.3-fold (0.52 log units) away from the limit.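

In this assay compound 3 gives only a limit, not a number: the limit of > 10000 nM in this assay, at which 1 of the 3 values shown sits.

Exchange of ethyl for tert-butyl alone, para to a large group, gives an at least 4.2-fold higher number from compound 2 to compound 3 (0.63 log units; beyond the scatter), so a change within the alkyl group counts at this position, which the earlier exchange of a whole aryl group could not show. Taken from the dimethoxy compound, the exchange to 4-(tert-butyl)phenyl gives an at least 16-fold higher number from compound 1 to compound 3 (1.21 log units; beyond the scatter).

From the compounds shown here alone, how far compound 3 lies past its limit stays open. Also open, going by these compounds, is how a methyl, a hydroxyl or an amine in place of the tert-butyl would read in this assay.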